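Hydrazone acylhydrazides on a shared chlorinated core: growth inhibition

The source may report more compounds than this note shows. Statements on the series, on what has been measured and on what is new or still open speak of the compounds shown alone.

Measured compounds:
compound 1 `Cc1cc2c(cc1C)C(Cl)=C(/C=N\NC(=O)C1=C(Cl)c3cc(C)c(C)cc3CCC1)CCC2` — > 100000 nM
compound 2 `Cc1cc2c(cc1C)C(Cl)=C(/C=N/NC(=O)c1ccccc1)CCC2` — > 100000 nM

In a functional assay on HeLa cells (Homo sapiens) for inhibition, read by sulforhodamine B assay, with a stated time of 48 h (a higher number here means a weaker inhibitor of growth, a lower number a stronger inhibitor of growth), compound 1 returns only a limit, > 100000 nM. In this assay compound 2 likewise returns only a limit, > 100000 nM. Going by the values given here, compound 2 therefore stands at the limit of > 100000 nM in this assay, at which 2 of the 2 values shown sit, and no step between measured compounds is available. Compound 3 `COc1cccc(C(=O)N/N=C/C2=C(Cl)c3cc(C)c(C)cc3CCC2)c1C` differs from compound 2 by 3-methoxy-2-methylphenyl in place of phenyl on a carbonyl carbon. With both known values at the limit, no direction for this change can be read from the data, and the step of a number no higher from compound 2 to compound 3 (the limit leaves the size open) is expected to stay within the scatter. Compound 3 is expected to give 100000 nM, between 30000 nM and 300000 nM.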

Compound 3, concentration for 50% growth inhibition: 300 nM
Beside the measured number, compound 3's estimate is 330-fold (2.52 log units) above it; measured number below the stated range.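

In this assay, the place on the carbonyl carbon turns out to be sensitive: 3-methoxy-2-methylphenyl in place of phenyl gives an at least 330-fold lower number from compound 2 to compound 3 (2.52 log units; beyond the scatter). Compound 3 is the first of the compounds shown to return a number rather than a limit, so the group at this place can decide whether growth inhibition is seen at all. The true size of the step stays open because compound 2 returns only a limit: the limit of > 100000 nM in this assay, at which 2 of the 3 values shown sit.

As far as these compounds go, the methoxy and methyl groups enter together, so their separate shares remain unknown. From the compounds shown here alone, whether an amine or a carboxylic acid on that phenyl ring would keep this activity also remains open.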